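The compounds below may be only part of what the source reports. "The series", "measured", "known", "first", "only" and "open" are said of these compounds alone.

Working notes on the series: in a functional assay on A549 cells (Homo sapiens) for antiproliferative activity, read by CCK-8 assay, with a stated time of 72 h (on this read-out higher numbers stand for weaker inhibition of growth and lower numbers for stronger inhibition of growth), compound 1 (`CCC1C(=O)N(C)c2cnc(Nc3ccc(S(=O)(=O)NCC(C)C)cc3)nc2N1c1ccn(C)n1`) gives 31600 nM, and compound 2 (`CC[C@@H]1C(=O)N(C)c2cnc(Nc3ccc(S(=O)(=O)NC)cc3)nc2N1C1CCCC1`) gives 183 nM. Compound 3 (`CCC1C(=O)N(C)c2cnc(Nc3ccc(S(=O)(=O)NCCO)cc3)nc2N1c1ccn(C)n1`) is reported as "not active" (no number reported), so it has no single number and no measured place on this scale. Compound 4 (`CCC1C(=O)N(C)c2cnc(Nc3ccc(S(=O)(=O)NCCCO)cc3)nc2N1c1ccn(C)n1`) departs from it by hydroxymethyl in place of hydroxy on a saturated chain carbon, two bonds along the chain from a sulfonamide nitrogen: hydroxymethyl in place of hydroxy on a saturated chain carbon, which also reads as 2-hydroxyethyl to 3-hydroxypropyl. For the measured compounds named here, with no measured step available, only a small step in this assay is expected, toward stronger inhibition of growth, leaving the result in the range of compound 1 at 31600 nM. For compound 4 the expected value is 30000 nM, with an estimated range of 10000 nM to 90000 nM.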

Compound 4, concentration for 50% growth inhibition: 48900 nM
Compound 4: the middle estimate sits 1.6-fold (0.21 log units) below what was measured; measured number inside the range.
By their numbers in this assay, from the lowest: compound 2; then compounds 1 and 4 (each within the scatter of the next).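

In this assay, 2-hydroxyethyl in place of isopropyl on a saturated chain carbon bound to a sulfonamide nitrogen gives a 1.5-fold higher number from compound 1 to compound 4 (0.19 log units; within the scatter), so the hydroxy-ended chain of compound 4 and the branched alkyl chain of compound 1 are not separated here. Compound 3 has no number, so its step to compound 4 cannot be read. Nothing available explains this result.

From the compounds shown here alone, an amine or a carboxylic acid at the end of this chain remains open, as does a longer chain such as 4-hydroxybutyl. Going by these compounds, how these chains read on the core of compound 2 is also open.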